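A few compounds are considered here, and "the series" means these few. Any claim that something is new, unique, unknown or untested is made for them only; others in the source may bear on it.

Measured so far:
Compound 1 `CCC[C@@H](CCO)Nc1nc(N)nc(C)c1Cc1ccc(CNC2CN(C)C2)cc1OC`: in an assay on HEK293 cells for agonist activity at Toll-like receptor 8 (Homo sapiens) (on this read-out higher numbers stand for an effect only at larger amounts of compound and lower numbers for an effect already at smaller amounts), compound 1 gives > 10000 nM, a limit of the assay and not a number.
Compound 2 `CCC[C@@H](CCO)Nc1nc(N)nc(C)c1Cc1ccc(CN(C)CC(N)=O)cc1OC`: in this assay compound 2 gives > 10000 nM, again a limit and not a number.
Compound 3 `CCC[C@@H](CO)Nc1nc(N)nc(C)c1Cc1ccc(CNCCO)cc1OC`: in this assay compound 3 gives 5370 nM.

Compound 2 thus stands at the limit of > 10000 nM in this assay, at which 2 of the 3 values shown sit, where compound 1 also sits; compound 3 alone reads as a number in this assay. Going by the values given here, the only step between two measured compounds that differ in one place, a step that the two limits leave unreadable from compound 1 to compound 2, runs from one limit to the other and gives no size.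

The next compound, compound 4 `CCC[C@@H](CCO)Nc1nc(N)nc(C)c1Cc1ccc(CNC)cc1OC`, differs from compound 2 by hydrogen in place of carbamoylmethyl on an amine nitrogen. Among the compounds with values here, no measured step bears on this change directly; the step from compound 1 to compound 2, exchanging one amine substituent for another on the same carbon, cannot be read. Compound 3 differs from compound 2 in two places, so its value says only that a secondary amine on this carbon can reach a readable number when the side chain is also changed.

An estimate can therefore rest on no readable step, and a step of an at least 1.1-fold lower number from compound 2 to compound 4 (0.04 log units; that floor lies within the scatter) is expected, which means no change beyond the scatter that the data can support. Compound 4 is expected to give 9000 nM in this assay, estimated between 2500 nM and 30000 nM, with a fair chance that only a limit is reported.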

Compound 4, half-maximal effective concentration: 6460 nM
For compound 4 the middle estimate is 1.4-fold (0.14 log units) above the measured one, and the stated range covers the measured number.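

With the rest of the structure kept from compound 1 and compound 2, compound 4 reads as a number in this assay: 6460 nM. Hydrogen in place of carbamoylmethyl on the amine nitrogen gives an at least 1.5-fold lower number from compound 2 to compound 4 (0.18 log units; that floor lies within the scatter), and methyl in place of 1-methylazetidin-3-yl on that nitrogen gives an at least 1.5-fold lower number from compound 1 to compound 4 (0.18 log units; that floor lies within the scatter). Both floors lie within the scatter, so neither step is shown to go beyond it, and the step between the two limits still cannot be read; each new step starts from a limit and not from a number, so only its floor is known: the limit of > 10000 nM in this assay, at which 2 of the 4 values shown sit.

From the compounds shown here alone, whether the small methylamino group itself matters, or only the loss of the larger substituents, stays open, as no other small substituent on this nitrogen, such as ethyl or cyclopropyl, stands beside compound 4. Also open, going by these compounds, is what a primary amine, with hydrogen in place of the remaining methyl, or a tertiary dimethylamino group would read at this nitrogen in this assay.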